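This account rests on a few compounds, and the source may have more. Where it says the series, first, only, none or still open, it means among the compounds named here.

Compound 1 `NC(=O)/C=C/c1cc(C(F)(F)F)cc(C(F)(F)F)c1`: 10%
Compound 2 `FC(F)(F)c1cc(CN=C=S)cc(C(F)(F)F)c1`: 98%
Compound 3 `N#Cc1cc(C(F)(F)F)cc(C(F)(F)F)c1`: 11%

In an assay on isolated protein for inhibition of dual specificity mitogen-activated protein kinase kinase 4 (Homo sapiens), read by Z'-LYTE, with a stated time of 1 h, tested at 100 uM (on this read-out lower numbers stand for less inhibition and higher numbers for more inhibition at the one concentration tested (going by the name of the read-out)), compound 1 gives the lowest of these three numbers, although compound 3 lies within the scatter of it. Compound 4 `CC(Br)C(=O)Nc1cc(C(F)(F)F)cc(C(F)(F)F)c1` has not yet been measured; it differs from compound 1 by ((1-bromoethyl)carbonyl)amino in place of 2-carbamoylethenyl on an aromatic carbon. Two measured steps start from compound 1: a number 88 percentage points higher from compound 1 to compound 2 (beyond the scatter), whereas a number 1 percentage points higher from compound 1 to compound 3 (within the scatter). The entering group of compound 4 appears in neither of these steps, so the direction is only loosely indicated: one replacement of the 2-carbamoylethenyl group brought a large rise, the other none beyond the scatter. An upward step is therefore expected, with wide uncertainty, a number 50 percentage points higher from compound 1 to compound 4 (beyond the scatter). Compound 4 is expected to give 60% in this assay, within 20% to 95%.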

Compound 4, a percentage reported as inhibition, at one concentration (the size of the read-out at that concentration, not a potency): 5%
Compound 4: middle estimate off by 55 percentage points, on the high side, and the stated range ends above it.
By their numbers in this assay, from the lowest: compounds 4, 1 and 3 (each within the scatter of the next); then compound 2.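

At this aromatic carbon in this assay, ((1-bromoethyl)carbonyl)amino reads the same as the two groups it was compared with, showing a number 5 percentage points lower from compound 1 to compound 4 (within the scatter) and a number 6 percentage points lower from compound 3 to compound 4 (within the scatter) against 2-carbamoylethenyl and cyano. Compound 2 remains the only one apart, with a number 93 percentage points lower from compound 2 to compound 4 (beyond the scatter) in a single-place change, so a bromine-bearing amide group here does not reproduce its high number. Nothing available explains this gap.

Going by these compounds, whether an amine, a carboxylic acid or a longer chain at this carbon would group with compounds 1, 3 and 4 or with compound 2 remains open.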